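The compounds below may be only part of what the source reports. "The series", "measured", "known", "first", "only" and "open" are said of these compounds alone.

Measured compounds in a functional assay on CHO-K1 cells for agonist activity at Glucose-dependent insulinotropic receptor (Homo sapiens), read by HTRF and cAMP accumulation, with a stated time of 30 min; on this read-out lower numbers stand for an effect already at smaller amounts and higher numbers for an effect only at larger amounts of compound:
Compound 1, `CC(C)(C)OC(=O)N1CCC(CCCNc2ccc3c(c2)CNC3=O)CC1`, gives 550 nM.
Compound 2, `CC(C)(C)OC(=O)N1CCC(CCCNc2ccc3c(c2)C(=O)CC3)CC1`, gives 46 nM.
Compound 3, `CCc1cnc(N2CCC(CCCNc3ccc4c(c3)OCC4=O)CC2)nc1`, gives 117 nM.

Compound 3 stands second highest of the three numbers: compound 2 lies lower, beyond the scatter, and compound 1 lies higher, also beyond the scatter. No pair of these compounds differs in only one place, so no single step within the measured set can be read off.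

Compound 4, `COC(=O)c1cnc(N2CCC(CCCNc3ccc4c(c3)OCC4=O)CC2)nc1`, differs from compound 3 by methoxycarbonyl in place of ethyl on an aromatic carbon. Among the measured compounds shown here, no measured step shows this exchange, so the expectation rests on the unchanged remainder of compound 3 alone. A small step, if any, is expected: a 1.4-fold higher number from compound 3 to compound 4 (0.14 log units; within the scatter), not clearly beyond the scatter in either direction. For compound 4 the estimate in this assay is 160 nM, with a range from 50 nM to 500 nM.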

Compound 4, half-maximal effective concentration: 149 nM
The estimate for compound 4 lay 1.1-fold (0.03 log units) above the measured number; the measured number falls inside the stated range.
By their numbers in this assay, from the lowest: compound 2; then compounds 3 and 4 (each within the scatter of the next); then compound 1.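

In this assay, among the compounds shown here, the change from 5-ethylpyrimidin-2-yl to 5-(methoxycarbonyl)pyrimidin-2-yl gives a 1.3-fold higher number from compound 3 to compound 4 (0.11 log units; within the scatter) and is the first single-place step. At this aromatic carbon, two atoms from the ring nitrogen, ethyl and methoxycarbonyl are therefore not told apart, although methoxycarbonyl carries hydrogen-bond acceptors and ethyl carries none. No measurement at hand bears on why the two groups read alike.

Open, as far as these compounds go, is whether a carboxylic acid, an amine or a longer chain on this carbon would also stay within the scatter of compound 3. A bare hydrogen at the same place is equally untested by the compounds shown.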